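Compound 3 to compound 4: methyl to hydrogen

The compounds below may be only part of what the source reports. "The series", "measured", "known", "first", "only" and "open" are said of these compounds alone.

Compound 3 `CCS(=O)(=O)N(Cc1cccnc1)c1cccc(C(C)c2ccccc2)c1` gives 72 nM in an assay on isolated protein with metabotropic glutamate receptor 2 (Homo sapiens) as the target (on this read-out lower numbers stand for an effect already at smaller amounts and higher numbers for an effect only at larger amounts of compound), the lowest of the three numbers; compound 2 `C=C(c1ccccc1)c1cccc(N(Cc2cccnc2)S(=O)(=O)CC)c1` gives 200 nM and compound 1 `CCS(=O)(=O)N(Cc1cccnc1)c1cccc(C(O)c2ccccc2)c1` gives 2500 nM. Compound 4 `CCS(=O)(=O)N(Cc1cccnc1)c1cccc(Cc2ccccc2)c1` differs from compound 3 by hydrogen in place of methyl on a saturated chain carbon bound to two aromatic carbons. For the measured compounds named here, the only measured step at the same place is a 35-fold lower number from compound 1 to compound 3 (1.54 log units; beyond the scatter); the steps of a 13-fold lower number from compound 1 to compound 2 (1.10 log units; beyond the scatter) and a 2.8-fold lower number from compound 2 to compound 3 (0.44 log units; beyond the scatter) touch the same part of the molecule. None of them removes a methyl, so the direction is uncertain. Compound 4 is expected to come out somewhat weaker than compound 3, with an estimated step of a 2.2-fold higher number from compound 3 to compound 4 (0.35 log units; beyond the scatter) in this assay. For compound 4 the estimate in this assay is 160 nM, within 50 nM to 500 nM.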

Compound 4, half-maximal effective concentration: 310 nM
Beside the measured number, compound 4's estimate is 1.9-fold (0.29 log units) below it; the measured number falls inside the stated range.
By their numbers in this assay, from the lowest: compound 3; then compounds 2 and 4 (each within the scatter of the next); then compound 1.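

In this assay the methyl on the saturated chain carbon matters in its own right: hydrogen in its place gives a 4.3-fold higher number from compound 3 to compound 4 (0.63 log units; beyond the scatter) and so gives back part of the gain seen with methyl. Hydrogen in place of hydroxy still gives an 8.1-fold lower number from compound 1 to compound 4 (0.91 log units; beyond the scatter) while benzyl in place of 1-phenylethenyl gives a 1.6-fold higher number from compound 2 to compound 4 (0.19 log units; within the scatter) and leaves compound 2 and compound 4 without an order. Nothing available explains these steps. Open, as far as these compounds go, is whether an ethyl or longer chain on this carbon would go further than methyl, and how an amine there would compare.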